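This account rests on a few compounds, and the source may have more. Where it says the series, first, only, none or still open, it means among the compounds named here.

Among the measured compounds shown here, in a functional assay on K562 cells (Homo sapiens) for antiproliferative activity, read by MTT assay, with a stated time of 24 h (a lower number here means a stronger inhibitor, a higher number a weaker inhibitor), compound 2 `COc1ccc(C(=O)/C=C/c2cccc([N+](=O)[O-])c2)c2c1C=CC(C)(C)O2` gives 5870 nM and compound 3 `COc1ccc(C(=O)/C=C/c2cccc(C(F)(F)F)c2)c2c1C=CC(C)(C)O2` gives 7850 nM as its value, so compound 2 sits within the scatter of its only numeric neighbour. Compound 1 `COc1ccc(C(=O)/C=C/c2ccc(-n3ccnc3)cc2)c2c1C=CC(C)(C)O2` reports only a limit of the assay (> 10000 nM). Compound 4 `COc1ccc(C(=O)/C=C/c2cccs2)c2c1C=CC(C)(C)O2` carries thiophen-2-yl in place of 3-nitrophenyl on a double-bonded chain carbon bound to a double-bonded chain carbon. For the measured compounds named here, the one measured step that bears on this is trifluoromethyl in place of nitro on an aromatic carbon (a 1.3-fold higher number from compound 2 to compound 3 (0.13 log units; within the scatter)), which lies within the scatter. The expected step in this assay (a 1.1-fold higher number from compound 2 to compound 4 (0.04 log units; within the scatter)) therefore stays within the scatter, with no direction favoured. Compound 4 is estimated at 6500 nM in a range from 2500 nM to 14000 nM as expected bounds.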

Compound 4, half-maximal inhibitory concentration: > 10000 nM
Compound 4 gave a limit, no number; the forecaster's own chance of this, stated with the estimate: 25%; at least 1.5-fold (0.18 log units) between middle value and limit.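

In this assay, thiophen-2-yl in place of 3-nitrophenyl on a double-bonded chain carbon bound to a double-bonded chain carbon gives an at least 1.7-fold higher number from compound 2 to compound 4 (0.23 log units; that floor lies within the scatter). Among the compounds shown here, this is the first reading of a change of the whole ring at this place, but it is only a floor, so the real size of the step cannot be read. Compound 4 shares with compound 1 a limit, not a number: the limit of > 10000 nM in this assay, at which 2 of the 4 values shown sit.

Going by these compounds, how far compound 4 lies past its limit stays open. Also open, on these data alone, is whether a 3-aminophenyl or a 3-carboxyphenyl at this place would give a value close to that of compound 2.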